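The source may hold more compounds than are shown below. What is called first, only, known or untested is meant among the compounds shown, and "the series" means these compounds.

Two compounds have numbers in an in vitro functional assay on HEK285-7 cells for antagonist activity at prostaglandin D2 receptor 2 (Homo sapiens), read by BRET and beta-arrestin recruitment; on this read-out higher numbers stand for weaker inhibition and lower numbers for stronger inhibition. Compound 1 `O=C(O)Cc1sc(NC(=O)c2ccccc2)nc1-c1ccc(Cl)cc1` gives 870 nM in this assay, and compound 2 `O=C(O)Cc1sc(C(c2ccc(F)cc2)c2ccc(F)cc2)nc1-c1cccc(F)c1` gives 18 nM in this assay. Compound 2 stands at the lower of the two numbers, and its gap to compound 1 lies beyond the usual scatter. Compound 3 `O=C(O)Cc1sc(C(c2ccc(F)cc2)c2ccc(F)cc2)nc1-c1ccnc(N2CCCC2)c1` has not been measured; it differs from compound 2 in one place: 2-(pyrrolidin-1-yl)pyridin-4-yl in place of 3-fluorophenyl on an aromatic carbon. Among the measured compounds shown here, no measured pair shows this change, so its size is unknown. For compound 3 the expected step is a 1.7-fold higher number from compound 2 to compound 3 (0.22 log units; within the scatter), small enough to fall within the scatter. For compound 3 the estimate in this assay is 30 nM, with a range from 8 nM to 120 nM.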

Compound 3, half-maximal inhibitory concentration: > 100000 nM
Compound 3 gave a limit, no number; the forecaster's own chance of this, stated with the estimate: 3%; middle value at least 3300-fold (3.52 log units) away from the limit.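

Compound 3 gave a limit and not a number: the limit of > 100000 nM in this assay, at which 1 of the 3 values shown sits. Putting 2-(pyrrolidin-1-yl)pyridin-4-yl in place of 3-fluorophenyl on this aromatic carbon gives an at least 5500-fold higher number from compound 2 to compound 3 (3.74 log units; beyond the scatter). Among the compounds shown here, the position is therefore far from indifferent to the group it carries, which the earlier compounds, differing in more than one place, could not show. On these data alone, it remains open whether a plain pyridin-4-yl, or a phenyl carrying a pyrrolidin-1-yl group, would keep inhibition at this position, and so which part of the entering group accounts for the loss.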